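A few compounds are considered here, and "the series" means these few. Any claim that something is new, unique, unknown or untested is made for them only; others in the source may bear on it.

Series notes. Compound 1 `Nc1ccccc1NC(=O)c1ccc(NC(=S)NCc2cccnc2)cc1` gives 116 nM in an assay on isolated protein for inhibition of Nicotinamide phosphoribosyltransferase (Homo sapiens), read by fluorescence, with stated times of 5 min and 15 min; a lower number here means a stronger inhibitor, a higher number a weaker inhibitor. Compound 2 `Nc1ccccc1NC(=O)c1ccc(NC(=S)NCc2cccc(Cl)c2)cc1` is the analogue with 3-chlorophenyl in place of pyridin-3-yl on a saturated chain carbon bound to an amide-type nitrogen. In this assay compound 2 gives > 2000 nM, which is a limit of the assay and not a number. The step is an at least 17-fold higher number from compound 1 to compound 2 (1.23 log units; beyond the scatter), so on the numbers shown compound 2 sits at the weak end, its value being only a bound, as reflected in the limit of > 2000 nM in this assay, at which 1 of the 2 values shown sits.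

Compound 3 `Nc1ccccc1NC(=O)c1ccc(NC(=S)NCc2cncc(Br)c2)cc1` is the next member: 5-bromopyridin-3-yl in place of 3-chlorophenyl on a saturated chain carbon bound to an amide-type nitrogen. Within the data shown here, the only measured step that bears on it is the one from compound 1 to compound 2, an at least 17-fold higher number from compound 1 to compound 2 (1.23 log units; beyond the scatter), which was large and went to weaker inhibition when the ring with one hetero atom was replaced by the ring of carbon only. Compound 3 brings back a ring with one hetero atom, so in this assay a large step toward a lower number, an at least 8.0-fold lower number from compound 2 to compound 3 (0.90 log units; beyond the scatter), is expected. For compound 3 the estimated value in this assay is 250 nM, with a range of 60 nM to 1200 nM.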

Compound 3, half-maximal inhibitory concentration: > 2000 nM
Compound 3: no number, only a limit; the forecaster's own chance of this, stated with the estimate: 12%; at least 8.0-fold (0.90 log units) between middle value and limit.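

In this assay compound 3 gives > 2000 nM, which is a limit of the assay and not a number, and the step from compound 2 to compound 3 cannot be read. The readable change is bromo in place of hydrogen on an aromatic carbon, an at least 17-fold higher number from compound 1 to compound 3 (1.23 log units; beyond the scatter), so the ring with one hetero atom on a saturated chain carbon bound to an amide-type nitrogen does not by itself secure a measurable value. Compound 1, with pyridin-3-yl, is now the only member with a number, while the 3-chlorophenyl of compound 2 and the 5-bromopyridin-3-yl of compound 3 both end at the limit: the limit of > 2000 nM in this assay, at which 2 of the 3 values shown sit.

The compounds shown leave open whether the loss in compound 2 follows from the chlorine or from the ring of carbon only, a question that plain phenyl on the same chain carbon would separate. They also leave open whether the bromo result extends to other groups on the same ring, such as 5-fluoropyridin-3-yl or 5-methylpyridin-3-yl.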